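Methoxy to Isopropoxy on a Chromone-Like Shared Core

The compounds below may be only part of what the source reports. "The series", "measured", "known", "first", "only" and "open" are said of these compounds alone.

Of the compounds shown here, three built on one shared core have been tested in a functional assay on KB cells (Homo sapiens) for antiproliferative activity, read by sulforhodamine B assay, with a stated time of 72 h; on this read-out higher numbers stand for weaker inhibition of growth and lower numbers for stronger inhibition of growth. Compound 1 `CCc1cc(=O)c2ccc(Sc3cccc(Cl)[n+]3[O-])c(C)c2o1` gives only a limit in this assay, > 28700 nM. Compound 2 `CCc1cc(=O)c2ccc(OCc3cccc(C#N)c3)c(C)c2o1` likewise returns a limit, > 31300 nM. Compound 3 `CCc1oc2c(C)c(OC)ccc2c(=O)c1Br` also returns a limit, > 33600 nM. Compound 3 therefore stands nowhere distinct among the numbers shown: every value is a limit, one sitting at the limit of > 28700 nM in this assay, at which 1 of the 3 values shown sits, one at the limit of > 31300 nM in this assay, at which 1 of the 3 values shown sits, and one at the limit of > 33600 nM in this assay, at which 1 of the 3 values shown sits, and no compound in this set shows a measured number in this assay.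

Compound 4 `CCc1oc2c(C)c(OC(C)C)ccc2c(=O)c1Br` differs from compound 3 in one place, (isopropyl in place of methyl on an oxygen on an aromatic ring), isopropyl in place of methyl on an oxygen on an aromatic ring. Within the data shown here, no step between measured compounds exists here, since none of the three gives a number to compare. The step from compound 3 to compound 4 is expected to be a step that the limit leaves unreadable from compound 3 to compound 4, which is nothing beyond the scatter in this assay in either direction. Compound 4 is thus expected to give about 35000 nM in this assay, within a range from 10000 nM to 100000 nM, and most probably the assay will again report only a limit for it.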

Compound 4, concentration for 50% growth inhibition: 22600 nM
Estimate against measurement, compound 4: 1.5-fold (0.19 log units) above, and the stated range covers the measured number.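

Compound 4 is the only compound shown that returns a number rather than a limit in this assay, so this position on the oxygen is the one place in the set where a change comes with a readable value. Isopropyl in place of methyl on an oxygen on an aromatic ring gives an at least 1.4-fold lower number from compound 3 to compound 4 (0.17 log units; that floor lies within the scatter), which means that the change can be tied to a measured number but that its printed size cannot be separated from the scatter. The true size of the step stays unknown, and only its floor can be given, because compound 3 has a limit and no number of its own: the limit of > 33600 nM in this assay, at which 1 of the 4 values shown sits.

On these data alone, how far the growth inhibition in this assay would move with a longer chain such as butoxy, or with an amine carried on a short chain at the same oxygen, remains open, as the set holds only methoxy and isopropoxy with the bromine in place. Compound 1 and compound 2 differ from compound 4 in more than one place, so they say nothing about this change.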